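The compounds below may be only part of what the source reports. "The series", "measured", "known", "first", "only" and "open" are said of these compounds alone.

Measured in a functional assay on HepG2 cells (Homo sapiens) for cytotoxicity, read by MTT assay, with a stated time of 48 h; a lower number here means a stronger inhibitor, a higher number a weaker inhibitor:
- compound 1 `O=C1/C(=C\c2ccc(Cl)cc2)S/C(=N/c2ccccc2)N1Cc1ccncc1`: 28800 nM
- compound 2 `CN(C)c1ccc(/C=C2/S/C(=N/c3ccccc3)N(Cc3ccncc3)C2=O)cc1`: 52600 nM

Going by the values given here, compound 2 stands within the scatter of compound 1, the only other compound measured. Compound 3 `O=C1/C(=C\c2ccc(O)c(O)c2)S/C(=N/c2ccccc2)N1Cc1ccncc1` has not yet been measured. It differs from compound 2 by one exchange, 3,4-dihydroxyphenyl in place of 4-(dimethylamino)phenyl on a double-bonded chain carbon bound to a double-bonded ring carbon: 3,4-dihydroxyphenyl in place of 4-(dimethylamino)phenyl.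

Among the compounds with values here, only one measured step bears on this change, dimethylamino in place of chloro on an aromatic carbon, and it is a 1.8-fold higher number from compound 1 to compound 2 (0.26 log units; within the scatter). So a change to this aromatic group has so far left this assay unmoved beyond the scatter. Within the data shown here, no measured compound carries hydroxyl groups, however, so this guide is thin. The expected result is no clear shift, with at most a slight lean towards compound 1: the estimated step is a 1.5-fold lower number from compound 2 to compound 3 (0.18 log units; within the scatter). For compound 3 the estimate is 35000 nM, with an expected range of 12000 nM to 85000 nM.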

Compound 3, half-maximal inhibitory concentration: 16200 nM
The estimate for compound 3 lay 2.2-fold (0.33 log units) above the measured number; low and high end bracket the measured number.
By their numbers in this assay, from the lowest: compounds 3, 1 and 2 (each within the scatter of the next, the first and the last beyond it).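

In this assay, the group on the double-bonded chain carbon bound to a double-bonded ring carbon can now move the number beyond the scatter: with 3,4-dihydroxyphenyl in place of 4-(dimethylamino)phenyl, the result is a 3.2-fold lower number from compound 2 to compound 3 (0.51 log units; beyond the scatter), a modest step. With the same group in place of 4-chlorophenyl, the result is a 1.8-fold lower number from compound 1 to compound 3 (0.25 log units; within the scatter), so compound 3 cannot be separated from compound 1, and the shift shows only against the 4-(dimethylamino)phenyl group. Nothing measured here explains the step.

Open, on these data alone, is whether a single hydroxyl group on the phenyl ring would give the same number as the pair, and whether methoxy groups in their place would. Also open, as far as these compounds go, is whether the step between these compounds holds in any cells other than those of this assay.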